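Swapping Chloro for Amino on a Purine Core

The compounds below may be only part of what the source reports. "The series", "measured", "known", "first", "only" and "open" are said of these compounds alone.

Measured so far:
compound 1, `ClCc1ccccc1Cn1cnc2c(Cl)nc(Cl)nc21`: 4670 nM
compound 2, `Nc1nc(Cl)c2ncn(Cc3ccc(CCl)cc3)c2n1`: 75900 nM
compound 3, `ClCc1ccc(Cn2cnc3nc(Cl)nc(Cl)c32)cc1`: 4070 nM

All three numbers come from a functional assay on A549 cells (Homo sapiens) for cytotoxicity, read by sulforhodamine B assay, with a stated time of 48 h; on this read-out higher numbers stand for weaker inhibition of growth and lower numbers for stronger inhibition of growth. Among them compound 1 stands second highest. Its nearest neighbour is compound 3, whose value lies within the usual scatter of compound 1, so the two cannot be told apart. The furthest is compound 2, whose higher number lies well beyond the scatter, meaning compound 2 inhibits growth far less strongly than compound 1.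

The unmeasured compound 4, `Nc1nc(Cl)c2ncn(Cc3ccccc3CCl)c2n1`, is derived from compound 1 by one change: amino in place of chloro on an aromatic carbon. Compound 2 already carries an amino group on its core where compounds 1 and 3 carry chloro, and in this assay compound 2 gives a much higher number than compound 3. Among the measured compounds shown here, no step between measured compounds has been worked out, so the size of the change can only be guessed from that comparison.

The expectation is that the step of a 13-fold higher number from compound 1 to compound 4 (1.11 log units; beyond the scatter) will be large and will point toward weaker growth inhibition. Compound 4 is therefore estimated at 60000 nM, in a range from 20000 nM to 180000 nM.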

Compound 4, concentration for total growth inhibition: 53700 nM
Compound 4: the middle estimate sits 1.1-fold (0.05 log units) above what was measured, within the range that was stated.
By their numbers in this assay, from the lowest: compounds 3 and 1 (each within the scatter of the next); then compounds 4 and 2 (each within the scatter of the next).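

In this assay, the step of an 11-fold higher number from compound 1 to compound 4 (1.06 log units; beyond the scatter) is the only comparison shown in which amino replaces chloro while the rest of the molecule stays the same. The large loss of growth inhibition can therefore be tied to this single change on the aromatic carbon between two ring nitrogen atoms. Compound 2 carries the same amino group but differs from compound 1 in a second place as well, so it could not isolate this change; compound 4 at 53700 nM and compound 2 at 75900 nM lie within the usual scatter of each other, so with amino in place, the other difference between these two has no visible effect in this assay.

There is no evidence here that explains why this swap has so large an effect. With only chloro and amino shown on this carbon, it remains open whether a methoxy group, a methylamino group or a plain hydrogen there would keep the growth inhibition of compound 1 or lose it as compound 4 does.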